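Para substituent swap on the anilide of the shared core

The compounds below may be only part of what the source reports. "The series", "measured", "known", "first", "only" and "open" are said of these compounds alone.

In a functional assay on NCI-H1975 cells (Homo sapiens) for inhibition, read by MTT assay, with a stated time of 72 h (on this read-out higher numbers stand for weaker inhibition and lower numbers for stronger inhibition), compound 1 `O=C(CSc1nc(Nc2ccccc2)c2ccccc2n1)Nc1ccccc1F` gives 9350 nM; compound 2 `O=C(CSc1nc(Nc2ccccc2)c2ccccc2n1)Nc1ccccc1Cl` gives 9610 nM; compound 3 `O=C(CSc1nc(Nc2ccccc2)c2ccccc2n1)Nc1ccc(Cl)cc1` gives 8040 nM. Compound 3 carries the lowest number of the three, but a 1.2-fold lower number from compound 1 to compound 3 (0.07 log units; within the scatter) and a 1.2-fold lower number from compound 2 to compound 3 (0.08 log units; within the scatter) both sit within the scatter, so no order among the three can be read from these numbers. The halogen exchange a 1.0-fold higher number from compound 1 to compound 2 (0.01 log units; within the scatter) likewise leaves the read-out unchanged.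

Compound 4 `O=C(CSc1nc(Nc2ccccc2)c2ccccc2n1)Nc1ccc(C(F)(F)F)cc1` is the next member, differing from compound 3 only in this: trifluoromethyl in place of chloro on an aromatic carbon. Among the measured compounds shown here, none of the measured steps exchanges chloro for trifluoromethyl, so there is no direct precedent. What the three steps show is that changing the substituent on the anilide ring, whether by halogen identity or by position, did not move this assay beyond its scatter. On that basis a step of similar size, in either direction or none, is expected from compound 3 to compound 4, namely a 1.0-fold lower number from compound 3 to compound 4 (0.00 log units; within the scatter). The value of compound 4 in this assay is therefore estimated at 8000 nM, with a range from 4000 nM to 16000 nM.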

Compound 4, half-maximal inhibitory concentration: 11700 nM
For compound 4 the middle estimate is 1.5-fold (0.17 log units) below the measured one; measured number inside the range.
By their numbers in this assay, from the lowest: compounds 3, 1, 2 and 4 (each within the scatter of the next).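

In this assay, the exchange of chloro (1 heavy atom) for trifluoromethyl (4 heavy atoms), on an aromatic carbon para to a large group, gives a 1.5-fold higher number from compound 3 to compound 4 (0.16 log units; within the scatter). This extends the flat picture beyond halogen exchange: a substituent with more heavy atoms than either halogen also leaves the read-out within the scatter at this position. The two wider comparisons agree, with a 1.2-fold higher number from compound 2 to compound 4 (0.09 log units; within the scatter) and a 1.3-fold higher number from compound 1 to compound 4 (0.10 log units; within the scatter), so all four anilides stand within the scatter and no order can be drawn among them, while no measurement on hand offers an account of this flat response.

From the compounds shown here alone, it remains open whether a substituent of another kind on this ring, such as an amine, a carboxylic acid or a longer alkyl chain, would move the number beyond the scatter. Going by these compounds, it is also open whether the anilide is a position that tolerates change in general or whether changes elsewhere on the shared core, such as on its phenylamino group, would shift the read-out from the level held by these four compounds.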